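A few compounds are considered here, and "the series" means these few. Any claim that something is new, unique, unknown or untested is made for them only; others in the source may bear on it.

Compound 2 (`Nc1nc2cc(-c3nn(CCCC(=O)NO)c4ncnc(N)c34)ccc2o1`) gives > 50000 nM in a functional assay on MCF7 cells (Homo sapiens) for inhibition, read by MTT assay, with a stated time of 72 h (on this read-out lower numbers stand for stronger inhibition and higher numbers for weaker inhibition), and that value is a limit of the assay, not a number. The unmeasured compound 4 (`Nc1nc2cc(-c3nn(CCCCC(=O)NO)c4ncnc(N)c34)ccc2o1`) differs from it by (hydroxycarbamoyl)methyl in place of hydroxycarbamoyl on a saturated chain carbon, three bonds along the chain from an aromatic nitrogen. For the measured compounds named here, only one measured step bears on this change, and it comes from a pair with another group on the shared core. Compound 1 (`Nc1ncnc2c1c(-c1cnc3[nH]ccc3c1)nn2CCCCCCCCC(=O)NO`) gives 24700 nM in this assay. Compound 3 (`Nc1ncnc2c1c(-c1cnc3[nH]ccc3c1)nn2CCCCCC(=O)NO`) gives > 150000 nM, which is again only a limit. Set against an at least 6.0-fold higher number from compound 1 to compound 3 (0.78 log units; beyond the scatter), a larger change of chain with the shorter chain on the higher side, the smaller change here is expected to give no step beyond the scatter, and any drift should lean towards a lower number. The expected step is an at least 1.1-fold lower number from compound 2 to compound 4 (0.04 log units; that floor lies within the scatter). For compound 4 the estimated value is 45000 nM, with an expected range from 15000 nM to 150000 nM.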

Compound 4, half-maximal inhibitory concentration: 14000 nM
Compound 4: the middle estimate sits 3.2-fold (0.51 log units) above what was measured; the measured number lies below the stated range.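

Lengthening the chain from 3-(hydroxycarbamoyl)propyl to 4-(hydroxycarbamoyl)butyl gives an at least 3.5-fold lower number from compound 2 to compound 4 (0.55 log units; beyond the scatter) in this assay, so on this core even this small change of chain can be read. For the compounds shown here, until now, the only step on chain length was an at least 6.0-fold higher number from compound 1 to compound 3 (0.78 log units; beyond the scatter), which came from another group on the shared core and a larger change of chain; here, too, the longer chain sits on the lower side. The value of compound 2 is only a limit, so the step gives a floor and its full size stays unknown: the limit of > 50000 nM in this assay, at which 1 of the 4 values shown sits.

From the compounds shown here alone, it remains open whether a longer chain on the core of compound 4 would lower the number further or whether the trend would turn. Going by these compounds, it is also open how a carboxylic acid or an amine would compare with the hydroxycarbamoyl group at the end of the same chain.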